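Sulfonyl aryl variation in a series sitting at the limit

This account rests on a few compounds, and the source may have more. Where it says the series, first, only, none or still open, it means among the compounds named here.

Compound 3 `CC(=O)Nc1ccc(S(=O)(=O)Nc2cccc(-c3nc(-c4ccc(NC(=O)c5cccnc5)cc4Cl)no3)c2)cc1Cl` is one of three compounds tested in a functional assay on MDA-MB-231 cells (Homo sapiens) for antiproliferative activity, read by MTT assay, with a stated time of 72 h (a higher number here means a weaker inhibitor, a lower number a stronger inhibitor), beside compound 1 `O=C(Nc1ccc(-c2noc(-c3cccc(NS(=O)(=O)c4ccccc4)c3)n2)c(Cl)c1)c1cccnc1` and compound 2 `Cc1ccc(S(=O)(=O)Nc2cccc(-c3nc(-c4ccc(NC(=O)c5cccnc5)cc4Cl)no3)c2)cc1`. In this assay compound 3 gives only a limit, > 10000 nM. Compound 1 likewise gives a limit, > 10000 nM. Compound 2 also gives a limit, > 10000 nM. The steps a step that the two limits leave unreadable from compound 1 to compound 2, a step that the two limits leave unreadable from compound 1 to compound 3 and a step that the two limits leave unreadable from compound 2 to compound 3 are therefore all of unreadable size, as the limit of > 10000 nM in this assay, at which 3 of the 3 values shown sit, shows. Compound 4 `CNC(=O)Nc1ccc(S(=O)(=O)Nc2cccc(-c3nc(-c4ccc(NC(=O)c5cccnc5)cc4Cl)no3)c2)cc1` differs from compound 3 by 4-((methylcarbamoyl)amino)phenyl in place of 4-acetamido-3-chlorophenyl on a sulfonyl sulfur. The measured changes on the sulfonyl sulfur give no readable size, so no step beyond the scatter can be expected in either direction. Compound 4 is expected to stay at the limit, estimated at 15000 nM with a range from 5000 nM to 50000 nM. The expected step is a step that the limit leaves unreadable from compound 3 to compound 4.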

Compound 4, half-maximal inhibitory concentration: 1300 nM
Estimate against measurement, compound 4: 12-fold (1.06 log units) above; the whole stated range lies above it.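

In this assay, the group on the sulfonyl sulfur now has a readable effect: 4-((methylcarbamoyl)amino)phenyl in place of 4-acetamido-3-chlorophenyl gives an at least 7.6-fold lower number from compound 3 to compound 4 (0.88 log units; beyond the scatter). (Methylcarbamoyl)amino in place of methyl on an aromatic carbon gives an at least 7.6-fold lower number from compound 2 to compound 4 (0.88 log units; beyond the scatter), and in place of hydrogen it gives an at least 7.6-fold lower number from compound 1 to compound 4 (0.88 log units; beyond the scatter). The steps among the other three compounds cannot be read: the limit of > 10000 nM in this assay, at which 3 of the 4 values shown sit.

The compounds shown do not separate the effect of the (methylcarbamoyl)amino group from that of losing the chlorine and the acetamido group together. On these data alone, whether an amine, a carboxylic acid or a longer chain at that place would give a similar number remains open.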